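From 4-Fluorophenyl to Amino on the Carbonyl Carbon

A few compounds are considered here, and "the series" means these few. Any claim that something is new, unique, unknown or untested is made for them only; others in the source may bear on it.

Compound 1 `COC1=CC(=O)c2c(c(CO)c(C3CC3)n2C)C1=O`: 820000 nM
Compound 2 `COC1=CC(=O)c2c(c(COC(=O)c3ccc(F)cc3)c(C)n2C)C1=O`: 300 nM

In a functional assay on V79-379A cells (Cricetulus griseus) for cytotoxicity, read by MTT assay, in the presence of a further agent that is not named here (on this read-out higher numbers stand for weaker inhibition and lower numbers for stronger inhibition), compound 2 gives 300 nM, the lowest of the two numbers measured, while compound 1 gives 820000 nM, a gap beyond the scatter. Compound 3 `COC1=CC(=O)c2c(c(COC(N)=O)c(C)n2C)C1=O` differs from compound 2 in one place: amino in place of 4-fluorophenyl on a carbonyl carbon. For the measured compounds named here, no step between measured compounds matches this change, and compound 1 differs from compound 2 in other places as well, so it offers no guide. A modest weakening is expected, a 3.3-fold higher number from compound 2 to compound 3 (0.52 log units; beyond the scatter), still within the usual range of such changes. Compound 3 is therefore estimated at 1000 nM, between 150 nM and 8000 nM.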

Compound 3, half-maximal inhibitory concentration: 300 nM
Estimate against measurement, compound 3: 3.3-fold (0.52 log units) above; the measured number falls inside the stated range.
By their numbers in this assay, from the lowest: compounds 2 and 3 (each within the scatter of the next); then compound 1.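

In this assay amino in place of 4-fluorophenyl on a carbonyl carbon brings no change at the digits printed from compound 2 to compound 3 (within the scatter) on this read-out. The carbonyl carbon can therefore carry either a single nitrogen or the much larger aromatic ring without a change beyond the scatter, which compound 1, differing in other places as well, could not show. Nothing measured here explains this outcome. Going by these compounds, whether dimethylamino or a longer chain such as butyl on the same carbonyl carbon would keep the number remains open.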